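This account rests on a few compounds, and the source may have more. Where it says the series, first, only, none or still open, it means among the compounds named here.

Working notes on the series, read in a functional assay on K562 cells (Homo sapiens) for inhibition, read by MTT assay, with a stated time of 72 h; on this read-out higher numbers stand for weaker inhibition and lower numbers for stronger inhibition. Compound 1 (`CCc1ccc(C(=O)/C=C/C(=O)O)cc1`) gives 5530 nM, and compound 2 (`CC(C)(C)c1ccc(C(=O)/C=C/C(=O)O)cc1`) gives 4330 nM. Only these two numbers are available so far, and compound 2 stands level with compound 1, its nearest neighbour, within the scatter. Compound 3 (`O=C(O)/C=C/C(=O)c1ccc(F)cc1`) departs from compound 2 by fluoro in place of tert-butyl on an aromatic carbon, with fluoro in place of tert-butyl on an aromatic carbon. Within the data shown here, one measured step bears on this change, at the same place: a 1.3-fold lower number from compound 1 to compound 2 (0.11 log units; within the scatter). Among the measured compounds shown here, that step swaps ethyl for tert-butyl, and no fluoro compound has been measured, so the data give no direct reading of this exchange. On these data alone, no step beyond the scatter is therefore expected in this assay, and the direction stays open. The expected value for compound 3 is 5500 nM, with an estimated range of 2500 nM to 12000 nM. The estimated step is a 1.3-fold higher number from compound 2 to compound 3 (0.10 log units; within the scatter).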

Compound 3, half-maximal inhibitory concentration: 16900 nM
For compound 3 the middle estimate is 3.1-fold (0.49 log units) below the measured one, outside the stated range (above it).
By their numbers in this assay, from the lowest: compounds 2 and 1 (each within the scatter of the next); then compound 3.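

In this assay this aromatic carbon proves sensitive to its substituent, which the exchange of ethyl for tert-butyl did not show: fluoro in place of tert-butyl gives a 3.9-fold higher number from compound 2 to compound 3 (0.59 log units; beyond the scatter), and fluoro in place of ethyl gives a 3.1-fold higher number from compound 1 to compound 3 (0.49 log units; beyond the scatter). Both steps are modest but beyond the scatter, so compound 3 stands apart from compound 1 and compound 2, which remain level with each other. No measurement at hand accounts for these steps.

The compounds shown leave open whether the higher number goes with fluoro itself or with a substituent of fewer heavy atoms, a question that chloro, methyl or methoxy at this place could address. Also open, on these data alone, is how an amine at this place would read, and whether the steps hold when the carboxylic acid of the shared core becomes a methyl ester.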